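The source may report more compounds than this note shows. Statements on the series, on what has been measured and on what is new or still open speak of the compounds shown alone.

Measured compounds:
compound 1 `O=C(Nc1ccc(Cl)cn1)C1CCCN(C(=O)c2cc(C(F)(F)F)cc(C(F)(F)F)c2)C1`: 0%
compound 2 `O=C(Nc1ccc(Cl)cc1)C1CCCN(C(=O)c2ccc(-c3ccco3)cc2)C1`: 6%

Both numbers come from an ADME assay on PC-3 cells (Homo sapiens) for cytotoxicity, read by WST assay, tested at 100 uM; a lower number here means less inhibition, a higher number more inhibition at the concentration tested (going by the name of the read-out). In this assay compound 1 gives 0% and compound 2 gives 6%; the two numbers sit within the scatter of each other, so nothing separates compound 1 from compound 2. Among the compounds with values here, compound 2 differs from compound 1 in more than one place and no single-point step connects the two, so the pair shows only that both read-outs are small at the tested concentration.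

Compound 3 `Cn1cnnc1-c1cccc(NC(=O)C2CCCN(C(=O)c3cc(C(F)(F)F)cc(C(F)(F)F)c3)C2)c1` is not yet measured. Against compound 1 it differs at one place: 3-(4-methyl-4H-1,2,4-triazol-3-yl)phenyl in place of 5-chloropyridin-2-yl on an amide-type nitrogen. Within the data shown here, no measured pair shows what such an exchange on the amide-type nitrogen does in this assay, so the expected size of the step rests on the two small read-outs alone. The expectation is for no step beyond the scatter, with a slight allowance upward, since the read-out of compound 1 at 0% cannot go lower. For compound 3 the estimate in this assay is 5%, within 0% to 20%, which means an expected step of a number 5 percentage points higher from compound 1 to compound 3 (within the scatter).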

Compound 3, a percentage reported as inhibition, at one concentration (the size of the read-out at that concentration, not a potency): 0%
Estimate against measurement, compound 3: 5 percentage points above; measured number inside the range.
By their numbers in this assay, from the lowest: compounds 1, 3 and 2 (each within the scatter of the next).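

In this assay, putting 3-(4-methyl-4H-1,2,4-triazol-3-yl)phenyl in place of 5-chloropyridin-2-yl on the amide-type nitrogen gives no change at the digits printed from compound 1 to compound 3 (within the scatter), and this is the only single-point step shown for the series. The exchange is not a small one: the entering group has 12 heavy atoms against 7, adds a five-membered aromatic ring with 3 hetero atoms, loses the chlorine and has 3 hydrogen-bond acceptors against 1, yet the read-out does not move beyond the scatter at the concentration tested. Nothing available bears on why the read-out stays flat at this position.

Still open, going by these compounds, is whether any group on this amide-type nitrogen lifts the read-out beyond the scatter, for example a phenyl carrying a primary amine or a carboxylic acid in place of the triazole. With a single tested concentration and one step at one position, the series gives no potency and no trend for the groups on this nitrogen.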